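Solubility in an amide-substituted pyrazole series

This account rests on a few compounds, and the source may have more. Where it says the series, first, only, none or still open, it means among the compounds named here.

Measured so far:
compound 1, `CCCNC(=O)c1cc(C(=O)NC)nn1[C@@H](C)c1ccccc1`, >= 132 ug/mL
compound 2, `CNC(=O)c1cc(C(=O)NC2CCOCC2)n([C@@H](C)c2ccccc2)n1`, 31 ug/mL

In a physicochemical assay for solubility (on this read-out lower numbers stand for lower solubility and higher numbers for higher solubility), compound 1 gives >= 132 ug/mL, which is a limit of the assay rather than a number. Among the compounds with values here, compound 2 is the only compound of the pair with a numerical value; in this assay compound 2 gives 31 ug/mL. Within the data shown here, the one measured step, an at least 4.2-fold lower number from compound 1 to compound 2 (0.62 log units; beyond the scatter), is read against the limit of >= 132 ug/mL in this assay, at which 1 of the 2 values shown sits, and is therefore known only as a lower bound on its size.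

Compound 3, `CNC(=O)c1cc(C(=O)N[C@H]2CC[C@H](O)CC2)n([C@@H](C)c2ccccc2)n1`, differs from compound 2 by 4-hydroxycyclohexyl in place of oxan-4-yl on an amide-type nitrogen. Among the measured compounds shown here, no measured step covers this change; the step from compound 1 to compound 2 concerns a different exchange on the same nitrogen and cannot be carried over. With nothing more to go on, compound 3 is expected to land near compound 2, with a step of about a 1.8-fold higher number from compound 2 to compound 3 (0.25 log units; within the scatter). The estimate for compound 3 in this assay is 55 ug/mL, with a range from 18 ug/mL to 170 ug/mL.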

Compound 3, solubility: >= 180 ug/mL
Compound 3: only a limit was reported; the forecaster's own chance of this, stated with the estimate: 25%; at least 3.2-fold (0.51 log units) between middle value and limit.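

Exchanging oxan-4-yl for 4-hydroxycyclohexyl on this amide-type nitrogen gives an at least 5.8-fold higher number from compound 2 to compound 3 (0.76 log units; beyond the scatter) in this assay. The low number of compound 2 therefore does not come with every six-membered ring at this position, since compound 3 also carries one there and sits far higher. In this read-out compound 3 gives >= 180 ug/mL, which is a limit of the assay and not a number, so the step is known only as a lower bound, read against this: the limit of >= 180 ug/mL in this assay, at which 1 of the 3 values shown sits.

As far as these compounds go, compound 1 and compound 3 both sit at limits, so the step between them cannot be read and their order stays unknown. Also open, from the compounds shown here alone, is what the hydroxy group contributes apart from the carbon ring, which a plain cyclohexyl or a 4-aminocyclohexyl group on the same nitrogen would help to separate.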